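This account rests on a few compounds, and the source may have more. Where it says the series, first, only, none or still open, it means among the compounds named here.

The measured compounds:
compound 1, `CC(C)(C)OC(=O)NCCCCNC(=O)CN1CN(c2ccccc2)C2(CCN(C(=O)c3ccc(C(C)(C)C)cc3)CC2)C1=O`, "not determined" (no result reported) in an assay on HEK293 cells for displacement of a labelled ligand from NPC1-like intracellular cholesterol transporter 1 (Homo sapiens); on this read-out higher numbers stand for weaker inhibition and lower numbers for stronger inhibition
compound 2, `CC(C)(C)c1ccc(C(=O)N2CCC3(CC2)C(=O)N(CC(=O)NCCC(=O)O)CN3c2ccccc2)cc1`, 11400 nM in this assay
compound 3, `CC(C)(C)c1ccc(C(=O)N2CCC3(CC2)C(=O)N(CC(=O)NCN)CN3c2ccccc2)cc1`, 26500 nM in this assay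

Going by these compounds, compound 1 stands nowhere on these numbers: no value was obtained for it, so its own potency is unknown. Compound 4, `CC(C)(C)OC(=O)NCCCCNC(=O)CN1CN(c2ccccc2)C2(CCN(C(=O)c3ccc(C4CCCCC4)cc3)CC2)C1=O`, differs from compound 1 by cyclohexyl in place of tert-butyl on an aromatic carbon. Among the measured compounds shown here, the only measured step, a 2.3-fold higher number from compound 2 to compound 3 (0.37 log units; beyond the scatter), concerns a different part of the shared core and so does not bear on the exchange of tert-butyl for cyclohexyl; no measured pair shows that exchange. With nothing to anchor it, the expectation for compound 4 can rest only on where the two measured compounds lie, which is weak inhibition in this assay. Compound 4 is therefore expected to give about 15000 nM, within 3000 nM to 80000 nM.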

Compound 4, half-maximal inhibitory concentration: 4600 nM
Compound 4: middle estimate off by 3.3-fold (0.51 log units), on the high side, within the range that was stated.
By their numbers in this assay, from the lowest: compound 4; then compound 2; then compound 3.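

Among the compounds shown here, compound 1 stands as "not determined" (no result reported) in this assay so no new step to compound 4 can be read. What exchanging tert-butyl for cyclohexyl does to inhibition stays open, and no evidence explains the result of compound 4.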